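Removing One Methyl from the Side Chain

A few compounds are considered here, and "the series" means these few. Any claim that something is new, unique, unknown or untested is made for them only; others in the source may bear on it.

In a functional assay on DU-145 cells (Homo sapiens) for cytotoxicity, read by MTT assay (on this read-out higher numbers stand for weaker inhibition and lower numbers for stronger inhibition), compound 1 `CC(C)=CC[C@@H](OC(=O)CCO)C1=CC(=O)c2c(O)ccc(O)c2C1=O` gives 55300 nM. Compound 2 `CCCC(O)CC(=O)O[C@H](CC=C(C)C)C1=CC(=O)c2c(O)ccc(O)c2C1=O` gives > 100000 nM, which is a limit of the assay and not a number. Going by the values given here, compound 3 `COC(C)CO[C@H](CC=C(C)C)C1=CC(=O)c2c(O)ccc(O)c2C1=O` gives 16600 nM, the lowest number of the series so far. Its standing rests on two steps beyond the scatter: a 3.3-fold lower number from compound 1 to compound 3 (0.52 log units; beyond the scatter) and an at least 6.0-fold lower number from compound 2 to compound 3 (0.77 log units; beyond the scatter).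

Compound 4 `COCCO[C@H](CC=C(C)C)C1=CC(=O)c2c(O)ccc(O)c2C1=O` differs from compound 3 by hydrogen in place of methyl on a saturated chain carbon bound to an oxygen on a saturated carbon and a saturated chain carbon, so that 2-methoxypropyl becomes 2-methoxyethyl. The nearest measured change at this kind of carbon is an at least 1.8-fold higher number from compound 1 to compound 2 (0.25 log units; that floor lies within the scatter). That step is only a floor within the scatter, and it involves a propyl group on a carbonyl-bearing chain, so it gives little guidance on the size of a methyl change. Compound 4 keeps the 2-methoxyethyl group in place of such a chain, and the lower number of compound 3 at 16600 nM is therefore expected to carry over largely intact. No step beyond the scatter is expected in this assay. The expected change is a 1.2-fold higher number from compound 3 to compound 4 (0.08 log units; within the scatter). For compound 4 the estimated value is 20000 nM, with an expected range from 8000 nM to 50000 nM.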

Compound 4, half-maximal inhibitory concentration: 43200 nM
Compound 4: the middle estimate sits 2.2-fold (0.33 log units) below what was measured; the range from low to high includes it.
By their numbers in this assay, from the lowest: compound 3; then compounds 4 and 1 (each within the scatter of the next). At a limit, above all of these: compound 2.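

In this assay, going by these compounds alone, this is the first step that isolates the methyl on the saturated chain carbon bound to an oxygen on a saturated carbon and a saturated chain carbon, and swapping it for hydrogen is not silent (a 2.6-fold higher number from compound 3 to compound 4 (0.42 log units; beyond the scatter)). Without that methyl, the 2-methoxyethyl group of compound 4 can no longer be told apart from the (2-hydroxyethyl)carbonyl group of compound 1 (a 1.3-fold lower number from compound 1 to compound 4 (0.11 log units; within the scatter)), so the ether chain alone does not reproduce the standing of compound 3. The step from compound 2 survives (an at least 2.3-fold lower number from compound 2 to compound 4 (0.36 log units; beyond the scatter)), but compound 2 is a limit of the assay and not a number, so the step is only a floor: the limit of > 100000 nM in this assay, at which 1 of the 4 values shown sits.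

Going by these compounds, whether an ethyl or a longer chain at this carbon would lower the number further stays open. So does the effect of an amine in place of the methoxy group.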